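A few compounds are considered here, and "the series" means these few. Any claim that something is new, unique, unknown or untested is made for them only; others in the source may bear on it.

Values in a functional assay on HeLa cells (Homo sapiens) for antiproliferative activity, read by MTT assay, with a stated time of 48 h (a higher number here means a weaker inhibitor, a lower number a stronger inhibitor), for the three measured compounds:
- Compound 1 `CCCCCCCCCCCCNc1nc2ccccc2nc1Oc1ccc(C(=O)N[C@@H](C)C(=O)OC)cc1` gives 28500 nM 
- Compound 2 `COC(=O)CNC(=O)c1ccc(Oc2nc3ccccc3nc2NC(C)(C)C)cc1` gives > 50000 nM as a limit
- Compound 3 `COC(=O)[C@H](C)NC(=O)c1ccc(Oc2nc3ccccc3nc2NC(C)(C)C)cc1` gives 55200 nM 

Compound 2 reads > 50000 nM and this is a limit of the assay, not a number. Going by the values given here, only two true numbers are therefore available. Compound 3 sits at 55200 nM and compound 1 at 28500 nM within the scatter of it.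

Compound 4 `COC(=O)[C@H](CC(C)C)NC(=O)c1ccc(Oc2nc3ccccc3nc2NC(C)(C)C)cc1` differs from compound 3 by isopropyl in place of hydrogen on a saturated chain carbon, two bonds along the chain from an amide-type nitrogen and a carbonyl carbon with isopropyl in place of hydrogen on a saturated chain carbon, two bonds along the chain from an amide-type nitrogen and a carbonyl carbon. Cut one bond further out, the change reads methyl to isobutyl.

The closest measured change is a step that the limit leaves unreadable from compound 2 to compound 3 with methyl in place of hydrogen on a saturated chain carbon bound to an amide-type nitrogen and a carbonyl carbon. The other measured step is a 1.9-fold higher number from compound 1 to compound 3 (0.29 log units; within the scatter) with tert-butyl in place of dodecyl on a nitrogen on an aromatic ring. With only these two steps to go on, no step beyond the scatter is expected in this assay and no direction is favoured.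

The estimate means a 1.2-fold lower number from compound 3 to compound 4 (0.09 log units; within the scatter) and this expected step stays within the scatter. Compound 4 is expected to fall between 20000 nM and 90000 nM with 45000 nM as the estimated middle.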

Compound 4, half-maximal inhibitory concentration: > 50000 nM
Compound 4: no number, only a limit; the forecaster's own chance of this, stated with the estimate: 30%; middle value at least 1.1-fold (0.04 log units) away from the limit.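

In this assay compound 4 gives > 50000 nM, which is a limit of the assay and not a number. No step can be read from compound 3 to compound 4 or from compound 2 to compound 4, because these comparisons run into the limit: the limit of > 50000 nM in this assay, at which 2 of the 4 values shown sit.

The compounds shown leave open what methyl to isobutyl does to the value of compound 3.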